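This account rests on a few compounds, and the source may have more. Where it says the series, first, only, none or still open, it means among the compounds named here.

In a physicochemical assay for solubility, in phosphate buffer, at pH 6.5 (on this read-out higher numbers stand for higher solubility and lower numbers for lower solubility), compound 1 (`CCOc1cc(CN2CCC(NC(=O)c3ccc(NC)nc3)CC2)cc(OCC)c1F`) gives 330 ug/mL and compound 2 (`CCOc1cc(CN2CCC(NC(=O)c3cncc(C)c3)CC2)cc(OCC)c1Cl`) gives 216 ug/mL, so these two numbers lie within the usual scatter of each other. Compound 3 (`CCOc1cc(CN2CCC(NC(=O)c3ccc(NC)nc3)CC2)cc(OCC)c1-c1ccc(F)cc1`) keeps the core of compound 1 but carries 4-fluorophenyl in place of fluoro on an aromatic carbon, ortho to two ethoxy groups: 4-fluorophenyl in place of fluoro on an aromatic carbon. Within the data shown here, no measured pair of compounds differs in only one place, so the data give no direct guide to this swap. A clear downward move beyond the scatter is expected, with the estimated change being a 6.6-fold lower number from compound 1 to compound 3 (0.82 log units; beyond the scatter). Compound 3 is estimated at 50 ug/mL, with an expected range from 10 ug/mL to 180 ug/mL.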

Compound 3, solubility: 153 ug/mL
Beside the measured number, compound 3's estimate is 3.1-fold (0.49 log units) below it; the range from low to high includes it.
By their numbers in this assay, from the lowest: compounds 3, 2 and 1 (each within the scatter of the next, the first and the last beyond it).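

In this assay, putting 4-fluorophenyl in place of fluoro on this aromatic carbon, ortho to two ethoxy groups, gives a 2.2-fold lower number from compound 1 to compound 3 (0.33 log units; beyond the scatter) as a modest step just beyond the scatter. Among these compounds, this is the first single-place comparison, and it shows that going from 1 heavy atom to 7 at this position costs only that modest step. No measurement shown gives a reason for this step. Still open, as far as these compounds go, is how an amine or a carboxylic acid would read at this position. Also open, from the compounds shown here alone, is whether the same swap would give a similar step on the core of compound 2.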